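Swapping an isoquinoline amide for a dienamide

The compounds below may be only part of what the source reports. "The series", "measured", "known", "first", "only" and "open" are said of these compounds alone.

Compound 3 `CCCCCCCCCCCCCCNC(=O)[C@@H](NC(=O)c1nccc2ccccc12)[C@@H](C)O` is an amide built on a shared core that carries a long chain on one side. In a functional assay on SiHa cells (Homo sapiens) for cytotoxicity, read by MTT assay, with a stated time of 48 h (on this read-out higher numbers stand for weaker inhibition and lower numbers for stronger inhibition), compound 3 gives 21600 nM. Among the numbers available, that is the lowest of the two: compound 1 `C/C=C/C=C/C(=O)N[C@H](C(=O)NCCCCCCCC)[C@@H](C)O`, which carries a different group on its carbonyl carbon, gives 123000 nM in this assay. For compound 2 `CCCCCCCCCCCCCCNC(=O)[C@@H](NC(=O)c1ccccc1)[C@@H](C)O` this assay reports only > 200000 nM, which is a limit of the assay rather than a number (the limit of > 200000 nM in this assay, at which 1 of the 3 values shown sits). Among the measured compounds shown here, the one measured step between close neighbours, an at least 9.2-fold lower number from compound 2 to compound 3 (0.96 log units; beyond the scatter), shows that the group sitting on the carbonyl carbon can move the result by a large amount.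

Compound 4 `C/C=C/C=C/C(=O)N[C@H](C(=O)NCCCCCCCCCCCCCC)[C@@H](C)O` differs from compound 3 in exactly that place: penta-1,3-dien-1-yl in place of isoquinolin-1-yl on a carbonyl carbon. For the measured compounds named here, no measured step covers this particular exchange. Going by the values given here, the only guide is compound 1, which carries the same penta-1,3-dien-1-yl group and gives 123000 nM in this assay, a weaker inhibition than compound 3 shows. Compound 4 is therefore expected to give a higher number, with an estimated step of a 4.2-fold higher number from compound 3 to compound 4 (0.62 log units; beyond the scatter). The estimate for compound 4 is 90000 nM, expected to fall between 30000 nM and 250000 nM.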

Compound 4, half-maximal inhibitory concentration: > 200000 nM
Compound 4 was reported as a limit; the forecaster's own chance of this, stated with the estimate: 25%; middle value at least 2.2-fold (0.34 log units) from the limit.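

In this assay, the result shows that the gain in compound 3 belongs to isoquinolin-1-yl itself, not merely to replacing phenyl with some other group on the carbonyl carbon: penta-1,3-dien-1-yl in that place gives an at least 9.2-fold higher number from compound 3 to compound 4 (0.96 log units; beyond the scatter) and so loses the gain. Compound 4 also adds a new comparison, hexyl in place of hydrogen on the saturated chain, which gives an at least 1.6-fold higher number from compound 1 to compound 4 (0.21 log units; that floor lies within the scatter) and therefore does not establish that the longer chain changes the result. Compound 2 and compound 4 are each reported as a limit, so the step between them cannot be read: the limit of > 200000 nM in this assay, at which 2 of the 4 values shown sit.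

Going by these compounds, it remains open whether the effect needs the whole isoquinolin-1-yl group or depends on its ring nitrogen, a question that a naphthyl group on the same carbonyl carbon would help to answer. Also open, on these data alone, is how compound 3 would respond if an octyl chain took the place of its long chain.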